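The source may hold more compounds than are shown below. What is called first, only, known or untested is meant among the compounds shown, and "the series" means these compounds.

Measured so far:
compound 1 `O=C(OCc1ccccc1)[C@@H]1CCCN1C(=O)CN(c1nc(Cl)nc2[nH]cnc12)C1CC1` — 34.4%
compound 2 `O=C(CN(c1nc(Cl)nc2[nH]cnc12)C1CC1)NCC(=O)OCc1ccccc1` — 41.9%
compound 3 `O=C(O)C[C@H](NC(=O)CN(c1nc(Cl)nc2[nH]cnc12)C1CC1)C(=O)O` — 38.9%

In a functional assay on the whole organism (Tail, strain ICR) with Mus musculus as the target, in the tail flick test, with a stated time of 60 min, at a dose of 25 umol/kg by the oral route (a lower number here means a weaker effect, a higher number a stronger effect of the compound at the dose given), compound 1 gives 34.4%, compound 2 gives 41.9% and compound 3 gives 38.9%. Compound 3 holds the second highest of the three numbers, but its gap to compound 2 and its gap to compound 1 both lie within the scatter, so the three measured compounds read as one level. Compound 4 `CC(C)C[C@H](NC(=O)CN(c1nc(Cl)nc2[nH]cnc12)C1CC1)C(=O)O` is not yet measured. The change from compound 3 is isopropyl in place of carboxy on a saturated chain carbon, two bonds along the chain from an amide-type nitrogen and a carbonyl carbon. Among the compounds with values here, no step between measured compounds is known, so nothing about the size of this change can be read off the series; with all three numbers at one level, the expected step of a number 0.9 percentage points lower from compound 3 to compound 4 (within the scatter) is none beyond the scatter. Compound 4 is estimated at 38%, between 22% and 55%.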

Compound 4, a percentage reported as activity, at one dose (the size of the read-out at that dose, not a potency): 36.4%
For compound 4 the middle estimate is 1.6 percentage points above the measured one; the measured number falls inside the stated range.
By their numbers in this assay, from the lowest: compounds 1, 4, 3 and 2 (each within the scatter of the next).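

In this assay, within the data shown here, isopropyl in place of carboxy on a saturated chain carbon gives a number 2.5 percentage points lower from compound 3 to compound 4 (within the scatter) and is the first readable step. At this position and dose, an all-carbon group with no hydrogen-bond donor or acceptor can therefore replace carboxy without a change beyond the scatter. No available evidence bears on this result. As far as these compounds go, whether an amine or a longer chain at this carbon would move the number beyond the scatter remains open, as does the effect of the opposite configuration there.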